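The compounds below may be only part of what the source reports. "The series", "measured", "known", "first", "only" and "open" are said of these compounds alone.

Compound 1 `COc1ccc(/C=C/C(=O)c2ccccc2-c2ccc(F)cc2)cc1OC` gives 95 nM
Compound 2 `COc1ccc(/C=C/C(=O)c2ccccc2-c2cccc(F)c2)cc1OC` gives 150 nM

In a functional assay on HepG2 cells (Homo sapiens) for antiproliferative activity, read by sulforhodamine B assay, with a stated time of 48 h (a lower number here means a stronger inhibitor, a higher number a weaker inhibitor), compound 2 gives 150 nM, which lies within the scatter of compound 1 at 95 nM. Compound 3 `COc1ccc(/C=C/C(=O)c2ccccc2-c2ccc(F)nc2)cc1OC` carries 6-fluoropyridin-3-yl in place of 3-fluorophenyl on an aromatic carbon. Within the data shown here, the only measured step, a 1.6-fold higher number from compound 1 to compound 2 (0.20 log units; within the scatter), exchanges 4-fluorophenyl for 3-fluorophenyl, and no measured compound holds a hetero atom in that ring. No step beyond the scatter is therefore expected in this assay, in either direction. The estimated step is a 1.1-fold higher number from compound 2 to compound 3 (0.05 log units; within the scatter). For compound 3 the expected value is 170 nM, with an estimated range from 60 nM to 500 nM.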

Compound 3, half-maximal inhibitory concentration: 1000 nM
Beside the measured number, compound 3's estimate is 5.9-fold (0.77 log units) below it; measured number above the stated range.
By their numbers in this assay, from the lowest: compounds 1 and 2 (each within the scatter of the next); then compound 3.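

In this assay, the group on this aromatic carbon, ortho to a large group, tolerates 3-fluorophenyl in place of 4-fluorophenyl but not the exchange for a ring with a hetero atom. Among these compounds, the change to 6-fluoropyridin-3-yl gives a 6.7-fold higher number from compound 2 to compound 3 (0.82 log units; beyond the scatter) and also an 11-fold higher number from compound 1 to compound 3 (1.02 log units; beyond the scatter) and so brings the first steps beyond the scatter in this short series. No measurement shown here accounts for these steps. Still open, going by these compounds, is whether the higher number follows the ring nitrogen alone, and how a pyridine ring carrying an amine or a methoxy group instead of fluorine would read.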